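Quinazoline thiosemicarbazides: from fluorophenyl to chlorophenyl

The source may report more compounds than this note shows. Statements on the series, on what has been measured and on what is new or still open speak of the compounds shown alone.

Of the compounds shown here, two have been tested in a functional assay on CNE-2 cells (Homo sapiens) for cytotoxicity, read by MTT assay, with a stated time of 72 h; a lower number here means a stronger inhibitor, a higher number a weaker inhibitor. Compound 1 `O=C(NC(=S)NNc1ncnc2ccccc12)c1ccc(F)cc1` gives 2840 nM in this assay, and compound 2 `COc1cc2ncnc(NNC(=S)NC(=O)c3ccc(C(F)(F)F)cc3)c2cc1OC` gives 16500 nM in this assay. Of the two numbers, compound 1 has the lower one, and the gap to compound 2 lies beyond the usual scatter. Compound 3 `O=C(NC(=S)NNc1ncnc2ccccc12)c1cccc(Cl)c1` differs from compound 1 in one place: 3-chlorophenyl in place of 4-fluorophenyl on a carbonyl carbon. Among the compounds with values here, no measured pair in this set shows what such an exchange of the benzoyl substituent does, so the expectation for compound 3 rests on compound 1 alone. The author expects the step of a 1.1-fold lower number from compound 1 to compound 3 (0.06 log units; within the scatter) to remain within the scatter, with no clear direction. For compound 3 the estimated value in this assay is therefore 2500 nM, with a plausible range from 800 nM to 8000 nM.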

Compound 3, half-maximal inhibitory concentration: 2920 nM
Compound 3: the middle estimate sits 1.2-fold (0.07 log units) below what was measured; measured number inside the range.
By their numbers in this assay, from the lowest: compounds 1 and 3 (each within the scatter of the next); then compound 2.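

In this assay the exchange of 4-fluorophenyl for 3-chlorophenyl on a carbonyl carbon gives a 1.0-fold higher number from compound 1 to compound 3 (0.01 log units; within the scatter), and this is the only measured pair shown that changes the benzoyl substituent on the shared core. It shows that this position accepts a different halogen, placed differently on the phenyl ring, with no change that can be told from the scatter of the measurement. No measured property or other supporting data bears on this result, so the pair offers no explanation for it.

Because the halogen and its place on the ring change together, the pair cannot separate the two, and 4-chlorophenyl would be needed to do so. Going by these compounds, whether the position accepts an amine or a carboxylic acid on the phenyl ring also remains open.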